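Trifluoromethyl in place of fluoro on the pendant phenyl

This account rests on a few compounds, and the source may have more. Where it says the series, first, only, none or still open, it means among the compounds named here.

Of the compounds shown here, two of a shared core have been measured. Compound 1 `Cc1ccc(-c2ccnc(C(=O)Nc3ccc(Oc4ccnc5[nH]ccc45)c(F)c3)c2)c(C)c1` gives 4350 nM in a functional assay on A549 cells (Homo sapiens) for cytotoxicity, read by MTT assay, with a stated time of 72 h (a lower number here means a stronger inhibitor, a higher number a weaker inhibitor), and compound 2 `O=C(Nc1ccc(Oc2ccnc3[nH]ccc23)c(F)c1)c1cc(-c2ccc(F)cc2)ccn1` gives 1090 nM in this assay. Of the two numbers, compound 2 holds the lower one; the step of a 4.0-fold lower number from compound 1 to compound 2 (0.60 log units; beyond the scatter) separates them, a modest change that arises from the 4-fluorophenyl in place of 2,4-dimethylphenyl on an aromatic carbon.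

Compound 3 `O=C(Nc1ccc(Oc2ccnc3[nH]ccc23)c(F)c1)c1cc(-c2ccc(C(F)(F)F)cc2)ccn1` has not been measured. It differs from compound 2 by trifluoromethyl in place of fluoro on an aromatic carbon, the change sitting para to a large group on the six-membered aromatic ring of carbon only, so that 4-fluorophenyl becomes 4-(trifluoromethyl)phenyl.

Going by the values given here, only the step from compound 1 to compound 2 bears on this change, and it concerns the same pendant ring; no measured pair shows what trifluoromethyl does in this place. Given that single modest step, a step of a 1.4-fold lower number from compound 2 to compound 3 (0.13 log units; within the scatter) is expected, with no firm direction. Compound 3 is accordingly estimated at 800 nM in this assay, within a range from 250 nM to 3000 nM.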

Compound 3, half-maximal inhibitory concentration: 4920 nM
For compound 3 the middle estimate is 6.2-fold (0.79 log units) below the measured one; the whole stated range lies below it.
By their numbers in this assay, from the lowest: compound 2; then compounds 1 and 3 (each within the scatter of the next).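

In this assay, the group para to a large group on the pendant phenyl ring proves to be a sensitive point: trifluoromethyl in place of fluoro gives a 4.5-fold higher number from compound 2 to compound 3 (0.65 log units; beyond the scatter), a step of about the same size as the earlier one but pointing the other way. The earlier compounds shown here showed only that 4-fluorophenyl gave a lower number than 2,4-dimethylphenyl, whereas a 1.1-fold higher number from compound 1 to compound 3 (0.05 log units; within the scatter) now puts 4-(trifluoromethyl)phenyl and 2,4-dimethylphenyl level within the scatter, leaving compound 2, with its steps to both others beyond the scatter, alone with the lowest number of the three. No measurement at hand accounts for this difference between fluoro and trifluoromethyl.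

The compounds shown leave open whether the lower number belongs to fluoro in particular or would also come with chloro, methyl, methoxy, an amine or a plain unsubstituted phenyl at this place. They also leave open whether the same gap between fluoro and trifluoromethyl would appear in any cell line other than this one, or on a core changed elsewhere.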